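Pyridin-2-yloxy variation on the shared core

The compounds below may be only part of what the source reports. "The series", "measured", "known", "first", "only" and "open" are said of these compounds alone.

Compound 1 `COC(=O)c1ccnc(O[C@@H]2CC[C@@H](C)N(C(=O)c3ccccc3-n3nccn3)C2)c1`: in a functional assay on CHO-K1 cells for antagonist activity at Orexin/Hypocretin receptor type 1 (Homo sapiens), read by FLIPR and calcium flux (on this read-out higher numbers stand for weaker inhibition and lower numbers for stronger inhibition), compound 1 gives 1800 nM.
Compound 2 `Cc1cccc(O[C@@H]2CC[C@@H](C)N(C(=O)c3ccccc3-n3nccn3)C2)n1`: in this assay compound 2 gives 745 nM.

Among the compounds with values here, compound 2 holds the lowest of the two numbers; the only step on record is a 2.4-fold lower number from compound 1 to compound 2 (0.38 log units; beyond the scatter). Compound 3 `C[C@@H]1CC[C@@H](Oc2cc(Br)ccn2)CN1C(=O)c1ccccc1-n1nccn1` carries 4-bromopyridin-2-yl in place of 6-methylpyridin-2-yl on an oxygen on a saturated carbon. Within the data shown here, no measured step involves a 4-bromopyridin-2-yl group; the single measured step exchanged groups on the same ring and was modest. A step of similar or smaller size, in either direction, is therefore expected in this assay. For compound 3 the estimate is 900 nM, range 300 nM to 2700 nM, meaning an expected 1.2-fold higher number from compound 2 to compound 3 (0.08 log units; within the scatter).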

Compound 3, half-maximal inhibitory concentration: 380 nM
The estimate for compound 3 lay 2.4-fold (0.37 log units) above the measured number; the measured number falls inside the stated range.
By their numbers in this assay, from the lowest: compounds 3 and 2 (each within the scatter of the next); then compound 1.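

In this assay, 4-bromopyridin-2-yl and 6-methylpyridin-2-yl on the oxygen cannot be told apart at this position (a 2.0-fold lower number from compound 2 to compound 3 (0.29 log units; within the scatter)). Bromo in place of methoxycarbonyl on the aromatic carbon gives a step beyond the scatter (a 4.7-fold lower number from compound 1 to compound 3 (0.68 log units; beyond the scatter)), so compound 1 now stands apart from both compound 2 and compound 3. No measurement shown offers an explanation for these steps.

Still open, going by these compounds, is how an amine or a carboxylic acid in place of bromo on the aromatic carbon would read. Also open, on these data alone, is whether chloro or a nitrile would stay level with bromo.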